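Imidazole carboxamide in place of methylpyrazole

The compounds below may be only part of what the source reports. "The series", "measured", "known", "first", "only" and "open" are said of these compounds alone.

Measured so far in a physicochemical assay for lipophilicity, using the shake flask method, in phosphate buffer, measured as octanol-water partition, with a stated time of 30 min, at pH 7.4; on this read-out lower numbers stand for lower lipophilicity and higher numbers for higher lipophilicity:
- compound 1, `Cn1cc(-c2cnc(NCc3c(F)ccc4c3CCO4)c3cn[nH]c(=O)c23)cn1`, gives 2.7
- compound 2, `O=C(Nc1ccccc1)c1cnc(NCc2c(F)ccc3c2CCO3)n2cnnc12`, gives 4.1
- compound 3, `Cc1ncccc1-c1cnc(NCc2c(F)ccc3c2CCO3)n2c(=O)[nH]nc12`, gives 3

Across these three numbers compound 1 sits at the low end, but its separation from compound 3 falls within the usual scatter of this assay, so the two cannot be told apart. Compound 2 stands clearly higher, beyond the scatter from compound 1.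

The next compound in the series is compound 4, `CNC(=O)c1ncc(-c2cnc(NCc3c(F)ccc4c3CCO4)c3cn[nH]c(=O)c23)n1C`. Relative to compound 1 the change is 1-methyl-2-(methylcarbamoyl)-1H-imidazol-5-yl in place of 1-methyl-1H-pyrazol-4-yl on an aromatic carbon. Going by the values given here, no measured pair in the set shows this kind of step, so the expectation rests on the change itself: the entering group is larger and brings a hydrogen-bond donor and an extra acceptor that the leaving group lacks. For compound 4 the step is expected to be a modest decrease, a number 0.40 log units lower from compound 1 to compound 4 (beyond the scatter), of about the size of the scatter or a little beyond it. Compound 4 is therefore estimated at 2.3, with a range from 1.8 to 2.9.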

Compound 4, distribution coefficient: 2.5
Beside the measured number, compound 4's estimate is 0.20 log units below it; the measured number falls inside the stated range.
By their numbers in this assay, from the lowest: compounds 4, 1 and 3 (each within the scatter of the next, the first and the last beyond it); then compound 2.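

Going by these compounds alone, this is the only step read so far at this position, on an aromatic carbon of a six-membered aromatic ring with 1 nitrogen: in this assay, 1-methyl-2-(methylcarbamoyl)-1H-imidazol-5-yl in place of 1-methyl-1H-pyrazol-4-yl gives a number 0.20 log units lower from compound 1 to compound 4 (within the scatter) for this change. The read-out does not separate the two groups, although the entering group has more heavy atoms, a hydrogen-bond donor and an additional hydrogen-bond acceptor. Nothing measured here accounts for this outcome.

Within the data shown here, the single pair does not show what the methylcarbamoyl group and the imidazole ring each contribute to the step. Also open, going by these compounds, is how the read-out would respond to a carboxylic acid or an amine in place of the methylcarbamoyl group on the same ring.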